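Notes on the step from compound 2 to compound 3

This account rests on a few compounds, and the source may have more. Where it says the series, first, only, none or still open, it means among the compounds named here.

- compound 1 `COc1cc2ncnc(Nc3ccc(NC(=O)c4ccc(Br)cc4)cc3)c2cc1OC`: 35000 nM
- compound 2 `COc1cc2ncnc(Nc3ccc(NC(=O)c4ccc(I)cc4)cc3)c2cc1OC`: 40000 nM

In a functional assay on HepG2 cells (Homo sapiens) for inhibition, read by MTT assay (a higher number here means a weaker inhibitor, a lower number a stronger inhibitor), compound 2 gives 40000 nM, and this lies within the scatter of compound 1 at 35000 nM, so the two cannot be ordered. The next compound is compound 3 `COc1cc2ncnc(Nc3ccc(NC(=O)c4cccc(C(F)(F)F)c4)cc3)c2cc1OC`, with 3-(trifluoromethyl)phenyl in place of 4-iodophenyl on a carbonyl carbon.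

Going by the values given here, only one measured step bears on this change: a 1.1-fold higher number from compound 1 to compound 2 (0.06 log units; within the scatter). It exchanges bromo for iodo on an aromatic carbon and stays within the scatter. Among the compounds with values here, it is weak evidence, since no measured compound carries a trifluoromethyl group and no measured step replaces iodo or bromo with one. With so little to go on, no step beyond the scatter is expected, and no direction can be argued with any confidence. The expected step is a 1.3-fold lower number from compound 2 to compound 3 (0.12 log units; within the scatter). The gap in the evidence calls for a wide range.

For compound 3 the estimated value is 30000 nM, with an expected range from 10000 nM to 80000 nM.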

Compound 3, half-maximal inhibitory concentration: 83000 nM
For compound 3 the middle estimate is 2.8-fold (0.44 log units) below the measured one; the whole stated range lies below it.
By their numbers in this assay, from the lowest: compounds 1 and 2 (each within the scatter of the next); then compound 3.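

In this assay the group on the carbonyl carbon can shift the number beyond the scatter, which the exchange of bromo for iodo did not show: 3-(trifluoromethyl)phenyl in place of 4-iodophenyl gives a 2.1-fold higher number from compound 2 to compound 3 (0.32 log units; beyond the scatter) and, in place of 4-bromophenyl, a 2.4-fold higher number from compound 1 to compound 3 (0.38 log units; beyond the scatter) with the same direction. Both steps are modest, yet they are enough to make compound 3 the weakest inhibitor of the three, while compound 1 and compound 2 remain impossible to order. No measured evidence bears on why the number rises with this change.

Compound 3 differs from compound 1 and compound 2 both in the group carried on the phenyl ring and in where the name places it, so the compounds shown cannot separate the trifluoromethyl group from its location. Also open, going by these compounds, are how 4-(trifluoromethyl)phenyl, or a phenyl carrying an amine or a carboxylic acid, would read on the same carbonyl carbon, and whether any group there can bring the number down rather than up.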